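This account rests on a few compounds, and the source may have more. Where it says the series, first, only, none or still open, it means among the compounds named here.

In a functional assay on HepG2 cells (Homo sapiens) for cytotoxicity, read by MTT assay, with a stated time of 48 h (on this read-out lower numbers stand for stronger inhibition and higher numbers for weaker inhibition), the measured compounds are:

compound 1 `CC(C)=CCC/C(C)=C/CC/C(C)=C/CC[C@@H]1[C@@]2(C)C/C(=C\c3ccc(OCc4cn(-c5ccc(Cl)cc5)nn4)cc3)C(=O)C(C)(C)[C@@H]2CC[C@@]1(C)O` gives 123000 nM

compound 2 `CC(C)=CCC/C(C)=C/CC/C(C)=C/CC[C@@H]1[C@@]2(C)C/C(=C\c3ccc(OCc4cn(-c5ccccc5C#N)nn4)cc3)C(=O)C(C)(C)[C@@H]2CC[C@@]1(C)O` gives 63100 nM

For the measured compounds named here, compound 2 sits at one end of the two numbers, with compound 1 as its only neighbour, and the step of a 1.9-fold lower number from compound 1 to compound 2 (0.29 log units; within the scatter) lies within the scatter, so the two are not separated in this assay. Compound 3 `CC(C)=CCC/C(C)=C/CC/C(C)=C/CC[C@@H]1[C@@]2(C)C/C(=C\c3ccc(OCc4cn(-c5cccc([N+](=O)[O-])c5)nn4)cc3)C(=O)C(C)(C)[C@@H]2CC[C@@]1(C)O` differs from compound 2 by 3-nitrophenyl in place of 2-cyanophenyl on an aromatic nitrogen. Going by the values given here, the one measured step that bears on this change is the step from compound 1 to compound 2, which also exchanged the aryl group on the same aromatic nitrogen and stayed within the scatter. On that basis no step beyond the scatter is expected here, in either direction, for the step of a 1.1-fold higher number from compound 2 to compound 3 (0.05 log units; within the scatter). The estimate for compound 3 is therefore 70000 nM, with a range from 25000 nM to 200000 nM.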

Compound 3, half-maximal inhibitory concentration: 117000 nM
Compound 3: middle estimate off by 1.7-fold (0.22 log units), on the low side; low and high end bracket the measured number.
By their numbers in this assay, from the lowest: compounds 2, 3 and 1 (each within the scatter of the next).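

In this assay, a third aryl group on the same aromatic nitrogen again fails to separate the compounds: the step of a 1.9-fold higher number from compound 2 to compound 3 (0.27 log units; within the scatter) lies within the scatter, as does the step of a 1.1-fold lower number from compound 1 to compound 3 (0.02 log units; within the scatter). For the compounds shown here, the earlier pair showed only one such exchange, whereas 4-chlorophenyl, 2-cyanophenyl and 3-nitrophenyl now cannot be told apart at this position, although a different group sits at a different place on the phenyl ring in each. No measured evidence bears on this result.

The compounds shown leave open whether an amine or a carboxylic acid on the phenyl ring, or a longer alkyl chain in place of the ring, would give a step beyond the scatter. They also leave open what the place on the phenyl ring does alone, since the group and its place change together in all three compounds.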